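Benzyl ether change on the shared core: working notes

This account rests on a few compounds, and the source may have more. Where it says the series, first, only, none or still open, it means among the compounds named here.

In a functional assay on HCT-116 cells (Homo sapiens) for antiproliferative activity, read by MTT assay, with a stated time of 24 h (a higher number here means a weaker inhibitor, a lower number a stronger inhibitor), compound 1 (`C#CCOc1ccc2c(=O)c(-c3cc(OC)c(OC)cc3OC)coc2c1`) gives 8050 nM. In the same assay, compound 2 (`COc1cc(OC)c(-c2coc3cc(OCc4cccc(F)c4)ccc3c2=O)cc1OC`) gives 4920 nM. For the measured compounds named here, the only measured step is a 1.6-fold lower number from compound 1 to compound 2 (0.21 log units; within the scatter), so compound 2 stands level with compound 1 on these two numbers, and neither can be ranked.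

Compound 3 (`COc1cc(OC)c(-c2coc3cc(OCc4ccc(Cl)cc4)ccc3c2=O)cc1OC`) has not yet been measured. It differs from compound 2 at one place: 4-chlorophenyl in place of 3-fluorophenyl on a saturated chain carbon bound to an oxygen on an aromatic ring. This puts 4-chlorophenyl in place of 3-fluorophenyl on a saturated chain carbon bound to an oxygen on an aromatic ring.

Going by the values given here, no measured pair exchanges one substituted phenyl for another, so direct precedent is lacking. The nearest evidence is the change from ethynyl to 3-fluorophenyl at the same place, which gave only a 1.6-fold lower number from compound 1 to compound 2 (0.21 log units; within the scatter). On that single step, no shift beyond the scatter is expected in this assay.

The expected step is a 1.1-fold lower number from compound 2 to compound 3 (0.04 log units; within the scatter).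

For compound 3 the estimated value is 4500 nM, with an expected range of 1800 nM to 11000 nM.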

Compound 3, half-maximal inhibitory concentration: 4450 nM
Estimate against measurement, compound 3: 1.0-fold (0.00 log units) above; the range from low to high includes it.
By their numbers in this assay, from the lowest: compounds 3, 2 and 1 (each within the scatter of the next).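

In this assay, for the compounds shown here, the exchange of 3-fluorophenyl for 4-chlorophenyl on a saturated chain carbon bound to an oxygen on an aromatic ring gives a 1.1-fold lower number from compound 2 to compound 3 (0.04 log units; within the scatter), the first measured step between two substituted phenyl groups at this place, and the two numbers cannot be told apart. Against the ethynyl group of compound 1, the 4-chlorophenyl group gives a 1.8-fold lower number from compound 1 to compound 3 (0.26 log units; within the scatter), so all three steps among these compounds now lie within the scatter and the three compounds stand as one level group. No available data bear on the reason these numbers sit together.

The compounds shown leave open whether any group at this place can move the number beyond the scatter, for example an amine or a carboxylic acid on the phenyl ring, or a longer chain between the oxygen and the ring. The step from compound 2 to compound 3 also changes the halogen and its location together, and 4-fluorobenzyl or 3-chlorobenzyl would be needed to read those two changes separately.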